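The source may hold more compounds than are shown below. What is called first, only, known or untested is meant among the compounds shown, and "the series" means these compounds.

Measured so far in a functional assay on MCF7 cells (Homo sapiens) for cytotoxicity, read by fluorescence, with a stated time of 72 h; on this read-out higher numbers stand for weaker inhibition and lower numbers for stronger inhibition:

compound 1 `CSc1nc(NCc2ccc(-c3ccccn3)cc2)c2[nH]nc(C(C)C)c2n1` — 819 nM
compound 2 `CC(C)c1n[nH]c2c(NCc3ccc(-c4ccccn4)cc3)nc(N[C@@H]3CCCC[C@H]3N)nc12` — 295 nM

Among the measured compounds shown here, compound 2 holds the lowest of the two numbers in this assay; its nearest neighbour is compound 1, and the one step between them, a 2.8-fold lower number from compound 1 to compound 2 (0.44 log units; beyond the scatter), exchanges methylsulfanyl for (2-aminocyclohexyl)amino on an aromatic carbon.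

The next compound, compound 3 `CC(C)c1n[nH]c2c(NCc3ccc(-c4ccccn4)cc3)nc(N[C@H]3CC[C@H](N)CC3)nc12`, keeps every atom of compound 2 but joins them differently: 4-aminocyclohexyl in place of 2-aminocyclohexyl on a nitrogen on an aromatic ring. Cut one bond further out, the same difference reads (2-aminocyclohexyl)amino to (4-aminocyclohexyl)amino.

For the measured compounds named here, no measured step bears on this change. Going by the values given here, the only step in hand, a 2.8-fold lower number from compound 1 to compound 2 (0.44 log units; beyond the scatter), concerns the arrival of the aminocyclohexyl group, not where its amine sits on the ring, so it gives no direction for moving the amine. The step to compound 3 is therefore expected to be small, likely within the scatter, with no direction favoured; the estimate is a 1.4-fold higher number from compound 2 to compound 3 (0.13 log units; within the scatter), carrying wide uncertainty in both directions. Compound 3 is thus expected at about 400 nM, with a range from 150 nM to 1200 nM.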

Compound 3, half-maximal inhibitory concentration: 474 nM
Estimate against measurement, compound 3: 1.2-fold (0.07 log units) below; the measured number falls inside the stated range.
By their numbers in this assay, from the lowest: compounds 2, 3 and 1 (each within the scatter of the next, the first and the last beyond it).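

In this assay, 4-aminocyclohexyl in place of 2-aminocyclohexyl on a nitrogen on an aromatic ring gives a 1.6-fold higher number from compound 2 to compound 3 (0.21 log units; within the scatter), so moving the amine around the cyclohexyl ring produces no difference that can be told from the scatter. The comparison with methylsulfanyl also becomes less firm: (4-aminocyclohexyl)amino gives a 1.7-fold lower number from compound 1 to compound 3 (0.24 log units; within the scatter), whereas (2-aminocyclohexyl)amino gives a 2.8-fold lower number from compound 1 to compound 2 (0.44 log units; beyond the scatter), so only compound 2 is separated from compound 1, and compound 3 goes against reading that separation as common to both aminocyclohexylamino groups. No available evidence accounts for either step.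

The compounds shown leave open whether 3-aminocyclohexyl on this nitrogen would also stay within the scatter of 2-aminocyclohexyl and 4-aminocyclohexyl, and whether the stereochemistry of the ring matters, since each of compound 2 and compound 3 appears as a single defined form. They also leave open whether the ring amine itself counts, which a hydroxyl in its place or an open-chain 2-aminoethyl group in place of the cyclohexyl ring could test.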